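Thiophen-3-yl in place of 4-chlorophenyl on the oxadiazoline carbon

The source may hold more compounds than are shown below. What is called first, only, known or untested is meant among the compounds shown, and "the series" means these compounds.

The series shares one core, carried in compound 1 `CC(=O)N1N=C(c2ccc3ccccc3c2)OC1c1ccc(Cl)cc1`, and varies the aryl group on a saturated ring carbon. In a functional assay on HepG2 cells (Homo sapiens) for antiproliferative activity, read by MTT assay, with a stated time of 48 h (a lower number here means a stronger inhibitor, a higher number a weaker inhibitor), compound 1 gives 1.88 ug/mL. Compound 2 `CC(=O)N1N=C(c2ccc3ccccc3c2)OC1c1ccccc1F` gives 3.36 ug/mL and compound 3 `CC(=O)N1N=C(c2ccc3ccccc3c2)OC1c1cccnc1` gives 2.86 ug/mL. Compound 1 holds the smallest of the three numbers, yet the steps of a 1.8-fold higher number from compound 1 to compound 2 (0.25 log units; within the scatter) and a 1.5-fold higher number from compound 1 to compound 3 (0.18 log units; within the scatter) are both within the scatter, as is a 1.2-fold lower number from compound 2 to compound 3 (0.07 log units; within the scatter), so the three compounds cannot be told apart.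

Compound 4 `CC(=O)N1N=C(c2ccc3ccccc3c2)OC1c1ccsc1` has not yet been measured. Relative to compound 1 the change is thiophen-3-yl in place of 4-chlorophenyl on a saturated ring carbon. The two measured steps at this same position, to compound 2 and compound 3, swap the aryl group for a different aromatic ring and stay within the scatter, so no step beyond the scatter is expected here either. Compound 4 is therefore estimated at 2.5 ug/mL, with a range of 1.2 ug/mL to 5.5 ug/mL, meaning an expected step of a 1.3-fold higher number from compound 1 to compound 4 (0.12 log units; within the scatter).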

Compound 4, half-maximal inhibitory concentration: 6.82 ug/mL
For compound 4 the middle estimate is 2.7-fold (0.44 log units) below the measured one; the measured number lies above the stated range.
By their numbers in this assay, from the lowest: compounds 1, 3 and 2 (each within the scatter of the next); then compound 4.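

Thiophen-3-yl is the first group on this saturated ring carbon to stand apart in this assay with a 3.6-fold higher number from compound 1 to compound 4 (0.56 log units; beyond the scatter) and a 2.4-fold higher number from compound 3 to compound 4 (0.38 log units; beyond the scatter) and also a 2.0-fold higher number from compound 2 to compound 4 (0.31 log units; beyond the scatter) as steps of a size that the changes among the earlier aryl groups did not give. The position therefore does not accept every aromatic ring alike, although 4-chlorophenyl, 2-fluorophenyl and pyridin-3-yl remain within the scatter of one another and a single compound sets no trend. Nothing measured here accounts for the higher number with thiophen-3-yl.

From the compounds shown here alone, whether that number goes with the five-membered ring or with the sulfur stays open, and furan-3-yl or pyrrol-3-yl on this carbon would separate the two. The compounds shown also leave open how an amine, a carboxylic acid or an open alkyl chain would read at this position.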